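Methyl for Fluoro on the Aryl Ring of Compound 1

This account rests on a few compounds, and the source may have more. Where it says the series, first, only, none or still open, it means among the compounds named here.

Three compounds have so far been examined in a functional assay on CHO-K1 cells for agonist activity at somatostatin receptor type 2 (Homo sapiens), read by cAMP accumulation, with a stated time of 30 min; a higher number here means that more compound is needed for the effect, a lower number that less compound is needed. Compound 1 `Cc1cc(F)cc(-c2cncc(-c3nc4cc(F)ccc4[nH]3)c2N2CCC(N)CC2)c1` gives 0.019 nM there. Compound 2 `Cc1cc(C)cc(-c2cncc(-c3nc4cc(C)cc(C)c4[nH]3)c2N2CCC(N)CC2)c1` gives 0.013 nM in this assay, and the two values lie within the usual scatter of each other, so no order between them can be claimed. Compound 3 `Cc1nn(C)cc1C(=O)Nc1cncc(-c2cc(Cl)cc(Cl)c2)c1N1CCC(N)CC1`, built on a different core, gives 0.12 nM in this assay, and its gap to compound 1 lies beyond the scatter; among the three numbers compound 1 thus has the second highest, with compound 3 clearly the higher one.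

Compound 4 `Cc1cc(C)cc(-c2cncc(-c3nc4cc(F)ccc4[nH]3)c2N2CCC(N)CC2)c1` has not yet been measured in this assay. It differs from compound 1 in one place: methyl in place of fluoro on an aromatic carbon, or, read one bond further out, 3-fluoro-5-methylphenyl becomes 3,5-dimethylphenyl. Going by the values given here, no measured pair shows this exact change on its own. Compound 2 carries the same 3,5-dimethylphenyl group and a differently substituted core, and its value in this assay sits within the scatter of compound 1. On that basis the step from compound 1 to compound 4 is expected to be small, a 1.3-fold lower number from compound 1 to compound 4 (0.10 log units; within the scatter), not beyond the scatter in either direction. Compound 4 is therefore estimated at 0.015 nM in this assay, with a range from 0.006 nM to 0.04 nM.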

Compound 4, half-maximal effective concentration: 0.013 nM
For compound 4 the middle estimate is 1.2-fold (0.06 log units) above the measured one, within the range that was stated.
By their numbers in this assay, from the lowest: compounds 2, 4 and 1 (each within the scatter of the next); then compound 3.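

Read in this assay, the exchange of fluoro for methyl, which turns 3-fluoro-5-methylphenyl into 3,5-dimethylphenyl, gives a 1.5-fold lower number from compound 1 to compound 4 (0.16 log units; within the scatter), and this is the first pair in which the change stands alone rather than alongside other differences in the core. On this one pair, the aromatic carbon meta to a large group and meta to a methyl group accepts methyl as well as fluoro, and the assay does not separate the two groups. Nothing available here speaks to why the two groups read alike.

The compounds shown carry only fluoro and methyl at this carbon, so they leave open whether the same position would accept a different kind of group, such as an amine, a carboxylic acid, a methoxy group or a longer chain. They also leave open whether the exchange of fluoro for methyl would read the same on another core, since this single pair is the only direct view of it.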